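The compounds below may be only part of what the source reports. "The series", "measured", "known", "first", "only" and "open" are said of these compounds alone.

Measured compounds:
compound 1, `O=C(Nc1cccc(Oc2ccccn2)c1)C1CCCN(C(=O)c2cc(C(F)(F)F)cc(C(F)(F)F)c2)C1`: 0%
compound 2, `N#Cc1cccc(C(=O)N2CCCC(C(=O)Nc3ccc(Cl)cc3)C2)c1`: 0%
compound 3, `Cc1nc(-c2cccc(C(=O)N3CCCC(C(=O)Nc4ccc(Cl)cc4)C3)c2)no1`: 0%

In an ADME assay on PC-3 cells (Homo sapiens) for cytotoxicity, read by WST assay, tested at 100 uM (on this read-out higher numbers stand for more inhibition at the one concentration tested (going by the name of the read-out) and lower numbers for less inhibition), compound 1 gives 0%, and on this read-out it stands level with compounds 2 and 3 at the digits shown; its nearest neighbour is compound 2 and its furthest is compound 3, yet neither gap exceeds the scatter. Going by the values given here, the only measured step within the set, no change at the digits printed from compound 2 to compound 3 (within the scatter), shows that swapping one substituent for another on an aromatic carbon of the shared core left the read-out flat.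

The step now followed goes from compound 1 to compound 4, `O=C(c1ccccc1)c1cccc(NC(=O)C2CCCN(C(=O)c3cc(C(F)(F)F)cc(C(F)(F)F)c3)C2)c1`, where (benzoyl in place of (pyridin-2-yl)oxy on an aromatic carbon). Among the compounds with values here, no measured step covers this exchange directly; the step from compound 2 to compound 3 bears on it only in that a change of group on an aromatic carbon produced nothing beyond the scatter, and all three measured compounds sit at the same floor. The expected change in this assay is therefore no change at the digits printed from compound 1 to compound 4 (within the scatter), none beyond the scatter. Compound 4 is estimated at 0%, within a range from -8% to 15%.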

Compound 4, a percentage reported as inhibition, at one concentration (the size of the read-out at that concentration, not a potency): 0%
Compound 4: the middle estimate sits on the measured number at the digits printed; the measured number falls inside the stated range.
By their numbers in this assay, from the lowest: compounds 1, 2, 3 and 4 (each within the scatter of the next).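

In this assay the step of no change at the digits printed from compound 1 to compound 4 (within the scatter) extends the flat picture to a new place: an aromatic carbon of a six-membered aromatic ring of carbon only, meta to a large group, on the core of compound 1. At this position, a benzoyl group, with its ring of carbon only and its carbonyl, reads the same as (pyridin-2-yl)oxy, whose ring holds a hetero atom, so this exchange of one aryl-bearing group for another leaves the read-out unmoved. Nothing available accounts for this lack of change.

The compounds shown leave open whether a basic amine or a carboxylic acid at this position would lift the read-out from the level of compound 4. They also leave open whether replacing either trifluoromethyl group would do so.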